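The source may report more compounds than this note shows. Statements on the series, on what has been measured and on what is new or still open speak of the compounds shown alone.

In a functional assay on A549 cells (Homo sapiens) for antiproliferative activity, read by XTT assay, with a stated time of 24 h (on this read-out lower numbers stand for stronger inhibition and higher numbers for weaker inhibition), compound 1 `Fc1ccc(C2CC(c3ccc(Cl)s3)=NN2c2nc(-c3ccc(Cl)cc3)cs2)cc1` gives 125 ug/mL. Compound 2 `Cc1ccc(C2=NN(c3nc(-c4ccc(F)cc4)cs3)C(c3ccc(F)cc3)C2)s1` gives the same number, 125 ug/mL, and compound 3 `Fc1ccc(C2CC(c3ccc(Cl)s3)=NN2c2nc(-c3ccc(Br)cc3)cs2)cc1` gives 62.5 ug/mL, so all three lie within the usual scatter of one another. Compound 4 `Fc1ccc(C2CC(c3ccc(Cl)s3)=NN2c2nc(-c3ccccc3)cs2)cc1` has not yet been measured. It differs from compound 1 by a single change, (hydrogen in place of chloro on an aromatic carbon), which turns 4-chlorophenyl into phenyl. For the measured compounds named here, the one measured step at that place, a 2.0-fold lower number from compound 1 to compound 3 (0.30 log units; within the scatter), puts bromo in place of chloro and stays within the scatter. Going by the values given here, no measured compound carries hydrogen there, so the expectation in this assay is no step beyond the scatter. The estimated step is no change at the digits printed from compound 1 to compound 4 (within the scatter). For compound 4, the expected value is 125 ug/mL, with an estimated range from 62.5 ug/mL to 250 ug/mL.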

Compound 4, half-maximal inhibitory concentration: > 500 ug/mL
Compound 4: a limit, no number (the forecaster's own chance of this, stated with the estimate: 8%); middle value at least 4.0-fold (0.60 log units) away from the limit.
By their numbers in this assay, from the lowest: compounds 3, 1 and 2 (each within the scatter of the next). At a limit, above all of these: compound 4.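

In this assay, exchanging chloro for bromo stayed within the scatter, but removing the halogen altogether does not: hydrogen in place of chloro gives an at least 4.0-fold higher number from compound 1 to compound 4 (0.60 log units; beyond the scatter), and hydrogen in place of bromo gives an at least 8.0-fold higher number from compound 3 to compound 4 (0.90 log units; beyond the scatter). Among these compounds, then, having chloro or bromo at this place on the ring goes with a measurable value, while plain phenyl does not. The result for compound 4 is a limit, not a number: the limit of > 500 ug/mL in this assay, at which 1 of the 4 values shown sits.

On these data alone, how far compound 4 really lies from the others remains open. So does how a methyl, a methoxy or an amine at this place would read.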